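The source may hold more compounds than are shown below. What is called first, only, known or untested is meant among the compounds shown, and "the series" means these compounds.

Three compounds of the series have numbers in a functional assay on HCT-15 cells (Homo sapiens) for cytotoxicity, read by sulforhodamine B assay, tested at 10 uM; on this read-out lower numbers stand for less inhibition and higher numbers for more inhibition at the one concentration tested (going by the name of the read-out): compound 1 `CCCc1cc(-c2cn([C@H]3C[C@H](OC(C)=O)[C@@H](COC(C)=O)O3)c(=O)[nH]c2=O)on1` gives 98.8%, compound 2 `CCCCCc1cc(-c2cn([C@H]3C[C@H](OC(C)=O)[C@@H](COC(C)=O)O3)c(=O)[nH]c2=O)on1` gives 98.7%, and compound 3 `CC(=O)OC[C@H]1O[C@@H](n2cc(-c3cc(-c4ccccc4)no3)c(=O)[nH]c2=O)C[C@@H]1OC(C)=O` gives 92.2%. On these numbers compound 3 holds the lowest value of the three, but both gaps are within the scatter: a number 6.6 percentage points lower from compound 1 to compound 3 (within the scatter) and a number 6.5 percentage points lower from compound 2 to compound 3 (within the scatter). Compound 4 `CCc1ccc(-c2cc(-c3cn([C@H]4C[C@H](OC(C)=O)[C@@H](COC(C)=O)O4)c(=O)[nH]c3=O)on2)cc1` differs from compound 3 by ethyl in place of hydrogen on an aromatic carbon. Among the compounds with values here, the steps that bear on this are the two just named, where propyl or pentyl gave way to phenyl on the same aromatic carbon without a change beyond the scatter; a number 0.1 percentage points lower from compound 1 to compound 2 (within the scatter) likewise stayed within the scatter. No step beyond the scatter is therefore expected in this assay. Compound 4 is estimated at 94%, with a range from 85% to 100%. The expected step is a number 1.8 percentage points higher from compound 3 to compound 4 (within the scatter).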

Compound 4, a percentage reported as inhibition, at one concentration (the size of the read-out at that concentration, not a potency): 92.2%
Estimate against measurement, compound 4: 1.8 percentage points above; low and high end bracket the measured number.
By their numbers in this assay, from the lowest: compounds 3, 4, 2 and 1 (each within the scatter of the next).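

In this assay, ethyl on the aromatic carbon para to a large group gives no change at the digits printed from compound 3 to compound 4 (within the scatter), so this first change on the phenyl ring itself produces no step beyond the scatter. The 4-ethylphenyl group also stands within the scatter of the two alkyl chains, with a number 6.5 percentage points lower from compound 2 to compound 4 (within the scatter) and a number 6.6 percentage points lower from compound 1 to compound 4 (within the scatter) in the comparisons with pentyl and propyl. Nothing available accounts for this result.

The compounds shown leave open whether an amine, a carboxylic acid or a chain longer than ethyl on this carbon would move the number beyond the scatter. They also leave open how these compounds differ at other concentrations.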